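Methoxy onto the outer phenyl of an EP4 acylsulfonamide

The compounds below may be only part of what the source reports. "The series", "measured", "known", "first", "only" and "open" are said of these compounds alone.

Compound 1, `Cc1oc(C(=O)NS(=O)(=O)c2ccccc2)cc1COc1ccc(-c2ccccc2)cc1`: 25 nM
Compound 2, `Cc1oc(C(=O)O)cc1COc1ccc(-c2ccc(CO)cc2)cc1`: 3000 nM

Of the compounds shown here, two have been measured in an assay on cells for displacement of a labelled ligand from prostaglandin E2 receptor EP4 subtype (Homo sapiens), read by scintillation counting; a higher number here means a weaker inhibitor, a lower number a stronger inhibitor. Compound 1 gives 25 nM and stands at the lowest number of the pair. Within the data shown here, compound 2 gives 3000 nM, a far higher number, well beyond the scatter; the two structures differ in more than one place, so the data show only that compound 2 is the weaker of the two, not which part of the change is responsible.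

The next compound, compound 3, `COc1ccc(-c2ccc(OCc3cc(C(=O)NS(=O)(=O)c4ccccc4)oc3C)cc2)cc1`, differs from compound 1 by a single change: methoxy in place of hydrogen on an aromatic carbon. Among the measured compounds shown here, no measured pair in this set isolates such a change, so its size must be judged from the structural change alone. A small substituent added to the outer phenyl of an already strong binder is expected to move the number in this assay by little, most likely not beyond the scatter, with a slight lean toward a lower number rather than a higher one. Compound 3 is therefore estimated at 20 nM, within 7 nM to 70 nM, a step of a 1.3-fold lower number from compound 1 to compound 3 (0.10 log units; within the scatter) expected from compound 1.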

Compound 3, inhibition constant in the prostaglandin E2 receptor EP4 subtype assay: 5 nM
Beside the measured number, compound 3's estimate is 4.0-fold (0.60 log units) above it; measured number below the stated range.
By their numbers in the prostaglandin E2 receptor EP4 subtype assay, from the lowest: compound 3; then compound 1; then compound 2.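

In the prostaglandin E2 receptor EP4 subtype assay, methoxy in place of hydrogen on the outer phenyl, para to a large group, gives a 5.0-fold lower number from compound 1 to compound 3 (0.70 log units; beyond the scatter). Among these compounds, this is the first change in the set made at a single place, so it shows what compound 1 and compound 2 could not: this position of an already strong binder accepts a methoxy group, and the phenyl to 4-methoxyphenyl change alone moves the binding number beyond the scatter. In a physicochemical assay for solubility, in phosphate buffer, with a stated time of 24 h, at pH 7.4 (a lower number here means a less soluble compound, a higher number a more soluble compound), compound 1 gives 2 ug/mL and compound 3 gives 11 ug/mL. The same change also brings a higher number in the physicochemical assay, so here stronger binding comes with better solubility rather than at its expense: the measured solubility of compound 1, 2 ug/mL, and of compound 3, 11 ug/mL, a 5.5-fold higher number (0.74 log units; beyond the scatter)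

One substituent at one position cannot show whether the gain belongs to methoxy itself or would also come with a fluorine, a hydroxyl, an amine or a longer chain such as ethoxy. Nor do the compounds shown say whether methoxy would act the same way elsewhere on that phenyl, or whether the same step in both read-outs would hold on a different acyl sulfonamide.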